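This account rests on a few compounds, and the source may have more. Where it says the series, first, only, none or still open, it means among the compounds named here.

Of the compounds shown here, two of a shared core have been measured in an assay on CHO cells for displacement of a labelled ligand from Substance-P receptor (Homo sapiens), with a stated time of 90 min; a higher number here means a weaker inhibitor, a lower number a stronger inhibitor. Compound 1, `Cc1nccc(-c2ccccc2)c1C(=O)N(C)Cc1cc(C(F)(F)F)cc(C(F)(F)F)c1`, gives 98 nM in this assay. Compound 2, `Cc1cc(-c2ccccc2)c(C(=O)NCc2cc(C(F)(F)F)cc(C(F)(F)F)c2)c(C)n1`, gives 434 nM in this assay, the higher of the two numbers; compound 1 stands nearest to it and lies beyond the usual scatter of the measurement, so compound 2 is the weaker inhibitor of the pair.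

Compound 3, `Cc1cc(-c2ccccc2)c(C(=O)N(C)Cc2cc(C(F)(F)F)cc(C(F)(F)F)c2)c(C)n1`, has not yet been measured. It differs from compound 2 in one place: methyl in place of hydrogen on an amide-type nitrogen whose other neighbours are a carbonyl carbon and a saturated chain carbon.

Among the measured compounds shown here, no measured pair in this small set isolates this change, so its effect can only be estimated. For compound 3 a lower number than for compound 2 is expected. The step in that direction is estimated to be a 2.7-fold lower number from compound 2 to compound 3 (0.43 log units; beyond the scatter), a size that should exceed the scatter but stay moderate. Compound 3 is therefore estimated to give about 160 nM in this assay, with a plausible range from 50 nM to 500 nM.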

Compound 3, half-maximal inhibitory concentration: 41 nM
The estimate for compound 3 lay 3.9-fold (0.59 log units) above the measured number, and the stated range ends above it.
By their numbers in this assay, from the lowest: compound 3; then compound 1; then compound 2.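

In this assay, among the compounds shown here, methyl in place of hydrogen on an amide-type nitrogen whose other neighbours are a carbonyl carbon and a saturated chain carbon gives an 11-fold lower number from compound 2 to compound 3 (1.02 log units; beyond the scatter), so this nitrogen, which no earlier pair could isolate, proves to be a place where a single added carbon changes the number greatly. With that methyl kept on the nitrogen, methyl in place of hydrogen on an aromatic carbon gives a 2.4-fold lower number from compound 1 to compound 3 (0.38 log units; beyond the scatter), a step that is modest where the one at the nitrogen is large, and both point towards the stronger inhibitor. Nothing given here bears on why either step has the size it has.

From the compounds shown here alone, it remains open whether the lower number at the amide-type nitrogen stops at methyl or carries over to an ethyl group or a longer chain, and what a chlorine atom or a methoxy group would do on the aromatic carbon in place of methyl. Each step also rests on a single pair of compounds, so neither can yet be said to hold on any other core.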